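A Phenyl Replaces the Methyl on the Shared Core

The compounds below may be only part of what the source reports. "The series", "measured", "known", "first", "only" and "open" are said of these compounds alone.

Compound 2 `Cc1nsc(OCC(O)CNC(C)(C)C)n1` has been measured in a functional assay on the whole organism (heart, strain mongrel) for inhibition, with Canis familiaris (Canis lupus familiaris) as the target, with a stated time of 20 min, at a dose of 0.1 mg/kg by the intravenous route (on this read-out lower numbers stand for a weaker effect and higher numbers for a stronger effect at the one dose given), where compound 2 gives 15%. Within the data shown here, the only other measured compound is compound 1 `CC(C)(C)NCC(O)COc1ncns1`, which in this assay gives 23.5%. The two are separated by a number 8.5 percentage points lower from compound 1 to compound 2 (within the scatter), so although compound 2 carries the lower of the two figures, the numbers cannot be told apart with confidence.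

Compound 3 `CC(C)(C)NCC(O)COc1nc(-c2ccccc2)ns1` has not yet been measured. It differs from compound 2 in a single place: phenyl in place of methyl on an aromatic carbon. Among the measured compounds shown here, no measured step speaks directly to this change. For the measured compounds named here, the one step that exists, placing a methyl on the same aromatic carbon in going from compound 1 to compound 2, stayed within the scatter, and a phenyl has not appeared anywhere among the measured compounds. The expectation for compound 3 therefore rests on thin ground, and a step no larger than the scatter is expected, no change at the digits printed from compound 2 to compound 3 (within the scatter), with wide uncertainty because a larger group is new here. For compound 3 the estimated read-out in this assay is 15%, expected to fall from 0% to 40%.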

Compound 3, a percentage reported as inhibition, in the whole organism at one dose (the size of the read-out at that dose, not a potency): 7%
Compound 3: middle estimate off by 8 percentage points, on the high side; low and high end bracket the measured number.
By their numbers in this assay, from the lowest: compounds 3, 2 and 1 (each within the scatter of the next, the first and the last beyond it).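

In this assay, putting phenyl in place of methyl on the aromatic carbon between two ring nitrogen atoms gives a number 8 percentage points lower from compound 2 to compound 3 (within the scatter), so this swap alone cannot be told apart from no change. Set against hydrogen on the same carbon, however, phenyl gives a number 16.5 percentage points lower from compound 1 to compound 3 (beyond the scatter), the only step so far that lies beyond the scatter, whereas methyl in place of hydrogen gives a number 8.5 percentage points lower from compound 1 to compound 2 (within the scatter); this position is therefore not indifferent to every group placed on it, although the effect is modest and rests on a single compound. Nothing measured here explains why the read-out follows this change.

As far as these compounds go, it remains open whether an intermediate group such as ethyl would fall nearer to methyl or to phenyl, and what an amine, a carboxylic acid or a phenyl ring bearing a chlorine would do on this carbon. From the compounds shown here alone, each figure also comes from one dose, so it shows only the size of the effect at that dose, and how these compounds would compare at other doses stays open too.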